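The source may report more compounds than this note shows. Statements on the series, on what has been measured and on what is new or still open speak of the compounds shown alone.

The measured compounds:

Compound 1, `C=C(c1ccc(OC)cc1NC(=O)CNCC)c1ccc(OC)c2c1OC(C)(C)C=C2`, gives 970 nM in a functional assay on A549 cells (Homo sapiens) for antiproliferative activity, read by MTT assay, with a stated time of 48 h; on this read-out higher numbers stand for weaker inhibition and lower numbers for stronger inhibition.
Compound 2, `C=C(c1ccc(OC)cc1NC(=O)CNCC)c1ccc(OC)c2c1C=CC(C)(C)O2`, gives 1870 nM in this assay.
Compound 3, `C=C(c1ccc(OC)cc1NC(=O)CN(C)C)c1ccc(OC)c2c1OC(C)(C)C=C2`, gives 270 nM in this assay.

Compounds 1 and 2 share the same side chain and differ only in their cores; the difference between the two cores is not broken down here. Their two numbers in this assay lie within the usual scatter of each other, so nothing can be said about an order between them.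

Compound 3 carries the core of compound 1 with a changed side chain: dimethylamino in place of ethylamino on a saturated chain carbon bound to a carbonyl carbon. This change gave a 3.6-fold lower number from compound 1 to compound 3 (0.56 log units; beyond the scatter), a step that lies beyond the scatter.

Compound 4, `C=C(c1ccc(OC)cc1NC(=O)CN(C)C)c1ccc(OC)c2c1C=CC(C)(C)O2`, is not yet measured. It stands to compound 2 as compound 3 stands to compound 1, namely (dimethylamino in place of ethylamino on a saturated chain carbon bound to a carbonyl carbon). The place of the change is the same in both pairs, so it is the same change on a different core. Within the data shown here, with only one measured example of this step, the expectation for compound 4 rests on that example alone. Because the step from compound 1 to compound 3 was a 3.6-fold lower number from compound 1 to compound 3 (0.56 log units; beyond the scatter), compound 4 is expected to show a step of about the same size from compound 2, a 3.6-fold lower number from compound 2 to compound 4 (0.56 log units; beyond the scatter), in this assay. On that basis compound 4 is estimated at 520 nM, expected to fall between 220 nM and 1300 nM.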

Compound 4, half-maximal inhibitory concentration: 550 nM
For compound 4 the middle estimate is 1.1-fold (0.02 log units) below the measured one; the measured number falls inside the stated range.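

In this assay, putting dimethylamino in place of ethylamino on a saturated chain carbon bound to a carbonyl carbon, this time on the core of compound 2, gave a 3.4-fold lower number from compound 2 to compound 4 (0.53 log units; beyond the scatter). Among these compounds, this evidence covers only two cores and a single pair of side chains in one cell line, so it cannot show that the step would hold on any other core, and the numbers alone do not say why the change lowers the value. Within these limits, the change carried over from one core to the other with its size intact, and the two cores give no sign of responding to it differently: the same change on two cores in this assay, a 3.6-fold lower number (0.56 log units; beyond the scatter) from compound 1 to compound 3 and a 3.4-fold lower number (0.53 log units; beyond the scatter) from compound 2 to compound 4, 1.1-fold (0.02 log units) apart, within the scatter of two such steps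

The compounds shown leave open whether the trend continues beyond dimethylamino, for instance with diethylamino, a primary amine, or a cyclic amine such as pyrrolidine, piperidine or morpholine in the same place. They also leave open whether a longer chain between the carbonyl and the amine would keep the step, and whether the same change behaves alike on cells other than those tested here.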